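Replacing 4-bromophenyl with pyridin-3-yl on the shared core

This account rests on a few compounds, and the source may have more. Where it says the series, first, only, none or still open, it means among the compounds named here.

In an ADME assay on Vero cells (Chlorocebus sabaeus) for cytotoxicity, read by MTT assay, with a stated time of 72 h (a lower number here means that less compound is tolerated, a higher number that more compound is tolerated), compound 1 `CN(C)c1ccc(/C=C/C(=O)c2ccc3c(c2O)C=CC(C)(C)O3)cc1` reaches only a limit of the assay, > 400000 nM. Compound 2 `CC(=O)Nc1ccc(/C=C/C(=O)c2ccc3c(c2O)C=CC(C)(C)O3)cc1` gives 279000 nM. Compound 3 `CC1(C)C=Cc2c(ccc(C(=O)/C=C/c3ccc(Br)cc3)c2O)O1` has no number, its result reading "not determined" (no result reported), so it offers no starting value. Compound 4 `CC1(C)C=Cc2c(ccc(C(=O)/C=C/c3cccnc3)c2O)O1` differs from compound 3 in one place: pyridin-3-yl in place of 4-bromophenyl on a double-bonded chain carbon bound to a double-bonded chain carbon. Among the compounds with values here, the sole measured step, an at least 1.4-fold lower number from compound 1 to compound 2 (0.15 log units; that floor lies within the scatter), concerns other groups and its floor lies within the scatter, so it supplies no size for this change. Within the data shown here, no particular step from compound 3 can therefore be expected in this assay, and the expectation rests on the level of compound 2 at 279000 nM. Compound 4 is expected near 280000 nM, with an estimated range of 100000 nM to 400000 nM.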

Compound 4, half-maximal cytotoxic concentration: 8600 nM
Estimate against measurement, compound 4: 33-fold (1.51 log units) above; the whole stated range lies above it.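

Within the data shown here, compound 3 reads "not determined" and compound 4 gives 8600 nM, so no step between them can be read. The compounds shown leave open how large the effect of pyridin-3-yl in place of 4-bromophenyl is, and in which direction it runs.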